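Cytotoxicity Outlook for Compound 4 on Vero Cells

The source may report more compounds than this note shows. Statements on the series, on what has been measured and on what is new or still open speak of the compounds shown alone.

Measured so far:
compound 1 `O=C(CCN1CCN(c2ccc(F)cc2)CC1)c1ccccc1` — 13400 nM
compound 2 `O=C(CCN1CCN(c2ccc(C(F)(F)F)cc2)CC1)c1ccccc1` — 15700 nM
compound 3 `COc1ccc(N2CCN(CCC(=O)c3ccc(F)cc3)CC2)cc1` — 31900 nM

In an ADME assay on Vero cells (Chlorocebus sabaeus) for cytotoxicity, read by resazurin assay, with a stated time of 72 h (on this read-out lower numbers stand for stronger inhibition and higher numbers for weaker inhibition), compound 2 gives 15700 nM, the second highest of the three numbers. Its nearest neighbour is compound 1, which in this assay gives 13400 nM; the step of a 1.2-fold higher number from compound 1 to compound 2 (0.07 log units; within the scatter) is within the scatter. Compound 3, which in this assay gives 31900 nM, stands furthest from compound 2, beyond the scatter.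

Compound 4 `O=C(CCN1CCN(c2ccc(C(F)(F)F)cc2)CC1)c1ccc(Cl)c(F)c1` differs from compound 2 by 4-chloro-3-fluorophenyl in place of phenyl on a carbonyl carbon. Within the data shown here, no measured step touches the phenyl on the carbonyl carbon: the only step on record, from compound 1 to compound 2, concerns the other aromatic ring and was within the scatter. Nothing therefore points to a change beyond the scatter, and the step of a 1.4-fold lower number from compound 2 to compound 4 (0.15 log units; within the scatter) is expected to be small, if anything toward a slightly lower number. Compound 4 is accordingly expected to give about 11000 nM in this assay, within a range from 4500 nM to 28000 nM.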

Compound 4, half-maximal inhibitory concentration: 74300 nM
For compound 4 the middle estimate is 6.8-fold (0.83 log units) below the measured one; measured number outside the range, above it.
By their numbers in this assay, from the lowest: compounds 1 and 2 (each within the scatter of the next); then compound 3; then compound 4.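

In this assay, the phenyl on a carbonyl carbon proves to be a place where the number can move beyond the scatter: 4-chloro-3-fluorophenyl in its place gives a 4.7-fold higher number from compound 2 to compound 4 (0.68 log units; beyond the scatter). Among these compounds, this goes in the direction of weaker inhibition, whereas the only earlier step, a 1.2-fold higher number from compound 1 to compound 2 (0.07 log units; within the scatter), concerned the other aromatic ring and showed no such movement. Nothing available bears on the reason for this rise.

The compounds shown do not separate the chloro from the fluoro part of the change, so it remains open whether one of them alone, or only the two together, goes with the step. Going by these compounds, it is also open whether a different group on this ring, such as an amine or a carboxylic acid, would move the number in the same direction.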